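The source may hold more compounds than are shown below. What is called first, only, known or untested is meant among the compounds shown, and "the series" means these compounds.

Working notes on the series

Two compounds in this set have a number in an assay on Sf9 cells for inhibition of protein deacetylase HDAC6 (Homo sapiens), read by fluorescence, with a stated time of 40 min; on this read-out higher numbers stand for weaker inhibition and lower numbers for stronger inhibition. Compound 1 `O=C(NO)c1ccc(NCc2nc(-c3cccs3)nn2-c2ccc(O)cc2)cc1` gives 33.5 nM. Compound 2 `O=C(NO)c1ccc(NCc2nc(-c3ccccc3)nn2-c2ccccc2Cl)cc1` gives 669 nM. On these two numbers compound 2 stands at the higher end: its value sits well apart from that of compound 1, beyond the usual scatter, so compound 2 is the weaker inhibitor of the pair. Compound 1 and compound 2 differ at more than one site, so no single change can be read off between them.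

Compound 3 `Cc1ccc(-n2nc(-c3ccccc3)nc2CNc2ccc(C(=O)NO)cc2)cc1` has not yet been measured in this assay. Its relation to compound 2 is a single change: 4-methylphenyl in place of 2-chlorophenyl on an aromatic nitrogen. Among the measured compounds shown here, no measured pair isolates this change, so the expectation rests only on the two numbers at hand.

The expectation is a moderate step toward a lower number, beyond the scatter, from compound 2 to compound 3 a 3.0-fold lower number from compound 2 to compound 3 (0.48 log units; beyond the scatter), though a result within the scatter of compound 2 cannot be excluded. Compound 3 is estimated at 220 nM, with a range from 60 nM to 800 nM.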

Compound 3, half-maximal inhibitory concentration: 310 nM
Beside the measured number, compound 3's estimate is 1.4-fold (0.15 log units) below it; measured number inside the range.
By their numbers in this assay, from the lowest: compound 1; then compound 3; then compound 2.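

Among the compounds shown here, this is the first single-place reading: 4-methylphenyl in place of 2-chlorophenyl on the aromatic nitrogen gives a 2.2-fold lower number from compound 2 to compound 3 (0.33 log units; beyond the scatter) in this assay. The step is modest but shows that this position responds to the choice of aryl group, even though both groups have one six-membered aromatic ring of carbon only, the same heavy-atom count and no hydrogen-bond donors or acceptors. The change replaces chlorine with methyl and also moves the substituent on the ring, so the step cannot be assigned to either alone, and nothing at hand accounts for it.

As far as these compounds go, how an unsubstituted phenyl on this nitrogen would read remains open, and it would show how much of the step belongs to losing the 2-chloro group and how much to gaining the 4-methyl group. Also open, from the compounds shown here alone, is how this position would respond to an amine, a carboxylic acid or a methoxy group on the aryl ring, since both compounds in this pair carry only a chlorine or a methyl there.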